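This account rests on a few compounds, and the source may have more. Where it says the series, first, only, none or still open, it means among the compounds named here.

Compound 2 `Oc1ccc(-c2cc(-c3ccoc3)cc(-c3cccc(O)c3)n2)cc1` carries a 3-hydroxyphenyl group, a 4-hydroxyphenyl group and a furan-3-yl group on a shared core. In a functional assay on DU-145 cells (Homo sapiens) for cytotoxicity, read by CCK-8 assay (a higher number here means a weaker inhibitor, a lower number a stronger inhibitor), compound 2 gives 2700 nM, and compound 1 `Oc1cccc(-c2cc(-c3ccoc3)cc(-c3ccccc3O)n2)c1` gives 2790 nM; the two numbers sit within the usual scatter of each other, as a 1.0-fold lower number from compound 1 to compound 2 (0.01 log units; within the scatter) shows. Compound 3 `Oc1ccc(-c2cc(-c3cccnc3)cc(-c3cccc(O)c3)n2)cc1` differs from compound 2 by pyridin-3-yl in place of furan-3-yl on an aromatic carbon. Among the compounds with values here, the one measured step concerns only the hydroxyphenyl groups and says nothing about this exchange, so no movement beyond the scatter is expected, no change at the digits printed from compound 2 to compound 3 (within the scatter). The estimate for compound 3 in this assay is 2700 nM, between 900 nM and 8000 nM.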

Compound 3, half-maximal inhibitory concentration: 6390 nM
Compound 3: the middle estimate sits 2.4-fold (0.37 log units) below what was measured, and the stated range covers the measured number.
By their numbers in this assay, from the lowest: compounds 2 and 1 (each within the scatter of the next); then compound 3.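

Unlike the earlier hydroxyphenyl exchange, the group opposite the ring nitrogen changes the reading in this assay: pyridin-3-yl in place of furan-3-yl gives a 2.4-fold higher number from compound 2 to compound 3 (0.37 log units; beyond the scatter), a modest step. Both groups are single aromatic rings with one hetero atom, so this position responds to a swap between a five-membered and a six-membered ring. Nothing measured here gives a reason for the rise. Going by these compounds, whether ring size or the hetero atom drives the step stays open. So does how a plain phenyl ring, an amine or a carboxylic acid would read at this position.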